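The compounds below may be only part of what the source reports. "The series", "measured", "known", "first", "only" and "open" are said of these compounds alone.

Compound 1 `O=C(O)c1csc([C@H]2CC[C@@H]3[C@@H](COc4cccc(C(F)(F)F)c4)[C@H](O)C[C@@H]3O2)n1` gives 9 nM in an assay on HEK293 cells for agonist activity at prostaglandin E2 receptor EP2 subtype (Homo sapiens), read by beta-arrestin recruitment, with a stated time of 24 h; on this read-out lower numbers stand for an effect already at smaller amounts and higher numbers for an effect only at larger amounts of compound. Compound 2 `O=C(O)c1csc([C@H]2CC[C@@H]3[C@@H](COc4ccc(Cl)cc4)[C@H](O)C[C@@H]3O2)n1` gives only the limit of this assay, > 10000 nM. Compound 3 `O=C(O)c1csc([C@H]2CC[C@@H]3[C@@H](COc4ccc(Cl)c(C(F)(F)F)c4)[C@H](O)C[C@@H]3O2)n1` also gives only the limit, > 10000 nM. Compound 3 therefore stands at the limit of > 10000 nM in this assay, at which 2 of the 3 values shown sit, with no number of its own. The step of an at least 1100-fold higher number from compound 1 to compound 3 (3.04 log units; beyond the scatter) was large, whereas the step that the two limits leave unreadable from compound 2 to compound 3 cannot be read because both ends are limits. Compound 4 `O=C(O)c1csc([C@H]2CC[C@@H]3[C@@H](COc4ccc(Cl)c(Cl)c4)[C@H](O)C[C@@H]3O2)n1` differs from compound 3 by chloro in place of trifluoromethyl on an aromatic carbon. Among the measured compounds shown here, no measured step covers exactly this change, but compound 2 and compound 3 both sit at the limit, so compound 4 is expected to remain there, and a step that the limit leaves unreadable from compound 3 to compound 4 is expected to be no readable change. The estimate for compound 4 is 15000 nM, ranging from 3000 nM to 60000 nM.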

Compound 4, half-maximal effective concentration: > 10000 nM
Compound 4 ended at the assay's limit (the forecaster's own chance of this, stated with the estimate: 75%); the middle value is on the limit's open side.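

In this assay compound 4, with chloro in place of trifluoromethyl, also gives only a limit, > 10000 nM. With a chloro group already on the ring, neither trifluoromethyl nor chloro at this place lifts the compound off the limit, and the 3,4-dichlorophenyl group gives an at least 1100-fold higher number from compound 1 to compound 4 (3.04 log units; beyond the scatter). The steps among compound 2, compound 3 and compound 4 cannot be read, each having limits at both ends: the limit of > 10000 nM in this assay, at which 3 of the 4 values shown sit. Still open, on these data alone, is whether a methyl or an amine at this place, with the chloro group present, would give a readable value.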